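The compounds below may be only part of what the source reports. "The series", "measured", "known", "first", "only" and "open" are said of these compounds alone.

Measured so far:
Compound 1, `CCOc1ccc(NC(=O)c2cccc(/C=C3\CC(=O)N(c4ccccc4)C3=O)c2)cc1`, gives 84800 nM.
Compound 2, `CCCCCN1C(=O)C/C(=C\c2cccc(C(=O)Nc3cccc(F)c3)c2)C1=O`, gives only a limit, > 100000 nM.
Compound 3, `COc1ccc(NC(=O)c2cccc(/C=C3\CC(=O)N(c4ccccc4)C3=O)c2)c(C)c1`, likewise gives only a limit, > 100000 nM.

These numbers come from an ADME assay on HCT-116 cells (Homo sapiens) for cytotoxicity, read by MTT assay, with a stated time of 72 h; a lower number here means a stronger inhibitor, a higher number a weaker inhibitor. Within them, compound 2 stands at the limit of the assay, a number rather than a value, so its standing against compound 1 cannot be ordered; the evidence for such limits is the limit of > 100000 nM in this assay, at which 2 of the 3 values shown sit.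

The unmeasured compound 4, `CCCCCN1C(=O)C/C(=C\c2cccc(C(=O)Nc3cccc(CC)c3)c2)C1=O`, differs from compound 2 in one place: ethyl in place of fluoro on an aromatic carbon.

For the measured compounds named here, only one measured step exists, an at least 1.1-fold higher number from compound 1 to compound 3 (0.07 log units; that floor lies within the scatter). That step sits on the amide-type nitrogen of a different pair and lies within the scatter, so it does not speak directly to a change on an aromatic carbon of the fluorophenyl ring. Going by the values given here, no measured pair shows fluoro against ethyl at that place.

Compound 4 is therefore expected to stay near its parent, with a step that the limit leaves unreadable from compound 2 to compound 4 as the estimated step, and most likely to return a limit as well. The estimate for compound 4 is 150000 nM, with a range from 60000 nM to 400000 nM.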

Compound 4, half-maximal inhibitory concentration: 75300 nM
The estimate for compound 4 lay 2.0-fold (0.30 log units) above the measured number, and the stated range covers the measured number.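

Ethyl in place of fluoro, on an aromatic carbon of the six-membered ring and meta to a large group, gives an at least 1.3-fold lower number from compound 2 to compound 4 (0.12 log units; that floor lies within the scatter) in this assay. This is the first step shown at this position, and with ethyl there, compound 4 returns a measured number while its fluoro parent does not. Only a floor can be given for this step, and that floor does not establish a real change, because compound 2 is a limit and not a number: the limit of > 100000 nM in this assay, at which 2 of the 4 values shown sit.

The compounds shown leave open whether a longer chain, an amine or a carboxylic acid at this place would move the number beyond the scatter. They also leave open whether ethyl in place of fluoro would read the same with phenyl in place of the pentyl chain.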